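The compounds below may be only part of what the source reports. "The series", "measured", "known", "first", "only" and "open" are said of these compounds alone.

Measured compounds in an ADME assay on Vero cells (Chlorocebus sabaeus) for cytotoxicity, read by resazurin assay, with a stated time of 3 days; on this read-out higher numbers stand for weaker inhibition and lower numbers for stronger inhibition:
Compound 1 `CCCCCC(=O)Nc1cc2nc(C3CCCCC3)[nH]c2cc1N1CCCC1` gives > 100 ug/mL, a limit of the assay.
Compound 2 `COc1ccc(C(=O)Nc2cc3nc(C4CCCCC4)[nH]c3cc2N2CCCC2)cc1` gives > 100 ug/mL, a limit of the assay.
Compound 3 `Cc1ccc(C(=O)Nc2cc3nc(C4CCCCC4)[nH]c3cc2N2CCCC2)cc1` gives > 100 ug/mL, a limit of the assay.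

Compound 3 thus stands only at a limit of this assay, as do the other two, per (the limit of > 100 ug/mL in this assay, at which 3 of the 3 values shown sit). The step from compound 3 to compound 4 `CCOCCOC(=O)Nc1cc2nc(C3CCCCC3)[nH]c2cc1N1CCCC1` is 2-ethoxyethoxy in place of 4-methylphenyl on a carbonyl carbon. The measured steps on the carbonyl carbon, a step that the two limits leave unreadable from compound 1 to compound 2 and a step that the two limits leave unreadable from compound 1 to compound 3, and on the aromatic carbon, a step that the two limits leave unreadable from compound 2 to compound 3, are all left unreadable by the limits, so no size can be read from them. With every value at the limit, compound 4 is expected to stay at the limit as well; the step that the limit leaves unreadable from compound 3 to compound 4 is an estimate of no change beyond the scatter. Compound 4 is therefore estimated at 150 ug/mL, between 50 ug/mL and 400 ug/mL.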

Compound 4, half-maximal inhibitory concentration: > 100 ug/mL
Compound 4: a limit, no number; the forecaster's own chance of this, stated with the estimate: 85%; the middle value is on the limit's open side.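

In this assay compound 4 gives > 100 ug/mL, a limit. No step from compound 1, compound 2 or compound 3 to compound 4 can be read: the limit of > 100 ug/mL in this assay, at which 4 of the 4 values shown sit.

The compounds shown leave open whether any group on the carbonyl carbon changes cytotoxicity.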